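This account rests on a few compounds, and the source may have more. Where it says the series, first, only, none or still open, it means among the compounds named here.

Measured so far in a toxicity assay on the whole organism (strain Icem-CET (SPF Caw)) for cytotoxicity, with Mus musculus as the target; a higher number here means that more compound is needed for the effect, a lower number that less compound is needed:
compound 1 `C#CCNC(=O)/C(C)=C(\C)c1ccc(Br)cc1` gives 500 mg/kg
compound 2 `C/C(C(=O)NC1CC1)=C(\C)c1ccc(C)cc1` gives 500 mg/kg

On the numbers shown, compound 1 stands level with compound 2 at the digits given; the two values lie within the scatter of each other, and no step between them is known, so nothing can be said of an order. Compound 3 `C=CCNC(=O)/C(C)=C(\C)c1ccc(Br)cc1` has not yet been measured in this assay. It differs from compound 1 by vinyl in place of ethynyl on a saturated chain carbon bound to an amide-type nitrogen. Within the data shown here, no step of this kind between measured compounds is available here, and the two measured compounds, which differ in several places at once, give no guide to it. The author therefore expects no step beyond the scatter, and estimates that from compound 1 to compound 3 the dose for half-maximal effect shifts by no change at the digits printed from compound 1 to compound 3 (within the scatter). Compound 3 is expected to give about 500 mg/kg, within a range from 250 mg/kg to 1000 mg/kg.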

Compound 3, dose for half-maximal effect: 500 mg/kg
Compound 3: the middle estimate sits on the measured number at the digits printed; the measured number falls inside the stated range.
By their numbers in this assay, from the lowest: compounds 1, 2 and 3 (each within the scatter of the next).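

In this assay, among these compounds, this pair gives the first reading of a single change at this position: with vinyl in place of ethynyl on a saturated chain carbon bound to an amide-type nitrogen, the step reads no change at the digits printed from compound 1 to compound 3 (within the scatter). The earlier compounds shown here differ in several places at once and could not isolate this position, whereas here propargylamino and allylamino, which carry the same count of heavy atoms and differ in a triple versus a double bond, stand level within the scatter. Nothing available accounts for this result.

One exchange of this kind does not show whether the position would stay level with a longer chain, such as butyl, or with a carboxylic acid or an amine on the same carbon. From the compounds shown here alone, whether propargyl and allyl would also stand level on another core remains open.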